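The compounds below may be only part of what the source reports. "The series", "measured", "known", "first", "only" and "open" are said of these compounds alone.

The compounds share the core seen in compound 1 `COc1ccc(S(=O)(=O)Nc2ccc(-c3nc4ccccc4o3)cc2)cc1` and differ only in the group on the sulfonyl sulfur. In an assay on cells for inhibition of HSP60/HSP10 (Homo sapiens), with a stated time of 60 min (a higher number here means a weaker inhibitor, a lower number a stronger inhibitor), compound 1 gives only a limit of the assay, > 100000 nM. Compound 2 `O=S(=O)(Nc1ccc(-c2nc3ccccc3o2)cc1)c1ccccc1F` likewise gives only a limit in this assay, > 100000 nM. Among the compounds with values here, compound 3 `COc1cccc(S(=O)(=O)Nc2ccc(-c3nc4ccccc4o3)cc2)c1` is the one compound with a number in this assay, 80000 nM. The other two values are the limit of > 100000 nM in this assay, at which 2 of the 3 values shown sit. The steps of an at least 1.2-fold lower number from compound 1 to compound 3 (0.09 log units; that floor lies within the scatter) and an at least 1.2-fold lower number from compound 2 to compound 3 (0.09 log units; that floor lies within the scatter) have floors that lie within the scatter, so they fix no order among the three. Compound 4 `O=S(=O)(Nc1ccc(-c2nc3ccccc3o2)cc1)c1ccc(Cl)c(Cl)c1` differs from compound 3 in one place: 3,4-dichlorophenyl in place of 3-methoxyphenyl on a sulfonyl sulfur. Within the data shown here, no measured step involves a 3,4-dichlorophenyl group, and the two steps that end at compound 3 give only floors, so there is little to build on. The expected step, a 1.3-fold lower number from compound 3 to compound 4 (0.12 log units; within the scatter), is therefore none beyond the scatter, with a fair chance that compound 4 returns only a limit in this assay. Compound 4 is estimated at 60000 nM, in a range from 15000 nM to 200000 nM.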

Compound 4, half-maximal inhibitory concentration: 25000 nM
Compound 4: the middle estimate sits 2.4-fold (0.38 log units) above what was measured; low and high end bracket the measured number.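

In this assay, within the data shown here, placing 3,4-dichlorophenyl on the sulfonyl sulfur gives a 3.2-fold lower number from compound 3 to compound 4 (0.51 log units; beyond the scatter), so, unlike the earlier steps, this one shows that the group at this position can move the number beyond the scatter. The other two steps, an at least 4.0-fold lower number from compound 2 to compound 4 (0.60 log units; beyond the scatter) and an at least 4.0-fold lower number from compound 1 to compound 4 (0.60 log units; beyond the scatter), are floors, yet they also lie beyond the scatter, which places compound 4 as the strongest of the four compounds shown. Compound 1 and compound 2 each still give only a limit of the assay: the limit of > 100000 nM in this assay, at which 2 of the 4 values shown sit.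

The compounds shown leave open whether a single chlorine on the phenyl ring would carry the same step or both chlorines are needed. Also open, on these data alone, is how a phenyl ring bearing an amine or a carboxylic acid, or a longer alkyl chain on the sulfonyl sulfur, would read in this assay.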